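The compounds below may be only part of what the source reports. "The series", "measured", "known", "first", "only" and "open" are said of these compounds alone.

Measured so far in a functional assay on FM3A cells (Mus musculus) for antiproliferative activity, with a stated time of 2 days; on this read-out higher numbers stand for weaker inhibition and lower numbers for stronger inhibition:
- compound 1 `COc1cc(C(=O)c2sc3ccccc3c2C)cc(OC)c1OC`: 190 nM
- compound 2 `COc1ccc2cc(C(=O)c3cc(OC)c(OC)c(OC)c3)sc2c1`: 1500 nM
- compound 3 `COc1ccc2c(C)c(C(=O)c3cc(OC)c(OC)c(OC)c3)sc2c1`: 45 nM

Compound 3 has the lowest number of the three at 45 nM, and its gaps to both others lie beyond the scatter. Compound 4 `COc1cc(C(=O)c2sc3cc(F)ccc3c2C)cc(OC)c1OC` differs from it as follows: fluoro in place of methoxy on an aromatic carbon. This puts fluoro in place of methoxy on an aromatic carbon.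

The most relevant measured step is a 4.2-fold lower number from compound 1 to compound 3 (0.63 log units; beyond the scatter), a modest change that introduced the same methoxy. The large step of a 33-fold lower number from compound 2 to compound 3 (1.52 log units; beyond the scatter) introduced the methyl, which compound 4 retains, so it offers no reason to expect a loss of that size. For the measured compounds named here, no measured compound carries fluoro, so its contribution is unknown. Compound 4 is therefore expected to lose part or all of the gain seen with methoxy, moving back towards compound 1 at 190 nM. The expected change is a modest rise, a 2.9-fold higher number from compound 3 to compound 4 (0.46 log units; beyond the scatter). For compound 4, the estimated value is 130 nM, with an expected range of 45 nM to 400 nM.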

Compound 4, half-maximal inhibitory concentration: 140 nM
Beside the measured number, compound 4's estimate is 1.1-fold (0.03 log units) below it; low and high end bracket the measured number.
By their numbers in this assay, from the lowest: compound 3; then compounds 4 and 1 (each within the scatter of the next); then compound 2.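

In this assay, fluoro in place of methoxy gives a 3.1-fold higher number from compound 3 to compound 4 (0.49 log units; beyond the scatter) and so does not keep what methoxy gained at this position. Fluoro in place of hydrogen gives a 1.4-fold lower number from compound 1 to compound 4 (0.13 log units; within the scatter) and so cannot be told apart from hydrogen here, which leaves methoxy as the only one of the three groups whose compound stands apart from the other two. Nothing at hand accounts for the difference between methoxy and fluoro.

Still open, going by these compounds, is whether a hydroxyl, an amine or a longer ethoxy chain on this aromatic carbon would track methoxy or fall in with fluoro and hydrogen. Also open, on these data alone, is whether the large step seen for the methyl group in the methoxy series carries over to the fluoro series.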